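The compounds below may be only part of what the source reports. "The series", "measured", "known", "first", "only" and "open" are said of these compounds alone.

Compound 1 `COc1cccc(CNCCCNc2ccnc3cc(Oc4ccccc4)ccc23)c1O` was measured in an ADME assay for permeability, using PAMPA, with a stated time of 30 min, at pH 7.4 (on this read-out higher numbers stand for higher permeability and lower numbers for lower permeability), where compound 1 gives 317 10^-6 cm/s. Compound 2 `CC(C)(C)c1ccc(Oc2ccc3c(NCCCNCc4ccco4)ccnc3c2)cc1` belongs to the same series, and in this assay compound 2 gives 317 10^-6 cm/s, a value level with that of compound 1 within the scatter. Compound 3 `COc1cccc(Oc2ccc3c(NCCCNCc4cccc(OC)c4O)ccnc3c2)c1` has not been measured. It differs from compound 1 by methoxy in place of hydrogen on an aromatic carbon. Among the compounds with values here, no step between measured compounds covers this change, so the expected step in this assay from compound 1 to compound 3 is estimated as no change at the digits printed from compound 1 to compound 3 (within the scatter), none beyond the scatter. For compound 3 the estimated value is 317 10^-6 cm/s, expected to fall between 160 10^-6 cm/s and 500 10^-6 cm/s.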

Compound 3, apparent permeability: 317 10^-6 cm/s
Beside the measured number, compound 3's estimate shows no gap at the digits printed, and the stated range covers the measured number.
By their numbers in this assay, from the lowest: compounds 1, 2 and 3 (each within the scatter of the next).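

In this assay, the change from phenoxy to 3-methoxyphenoxy gives no change at the digits printed from compound 1 to compound 3 (within the scatter) and so shows that this place on the ring takes methoxy without a step in the read-out. Compounds 1 and 2 differ in more than one place and could not show this for any single change. Nothing measured here bears on why the read-out stays level.

On these data alone, whether an amine or a carboxylic acid at this place would leave the read-out level stays open. So does whether the same holds for a longer chain between the shared core and the amine.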